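A ring on the carbonyl after the lowest number

This account rests on a few compounds, and the source may have more. Where it says the series, first, only, none or still open, it means among the compounds named here.

Of the compounds shown here, three sharing one core have been measured in a functional assay on HeLa cells (Homo sapiens) for cytotoxicity, read by MTT assay; a higher number here means a weaker inhibitor, a lower number a stronger inhibitor. Compound 1 (`CC(C)=CC[C@@H](OC(=O)c1ccco1)C1=CC(=O)c2c(O)ccc(O)c2C1=O`) gives 80300 nM, compound 2 (`CCCCC(O)CC(=O)O[C@H](CC=C(C)C)C1=CC(=O)c2c(O)ccc(O)c2C1=O`) gives 72200 nM, and compound 3 (`CC[C@](C)(O)CC(=O)O[C@H](CC=C(C)C)C1=CC(=O)c2c(O)ccc(O)c2C1=O`) gives 30200 nM. Compound 3 therefore holds the lowest number of the three, modestly but beyond the scatter against each of the others.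

Compound 4 (`CC(C)=CC[C@@H](OC(=O)C1CCOC1)C1=CC(=O)c2c(O)ccc(O)c2C1=O`) departs from compound 3 on a carbonyl carbon: oxolan-3-yl in place of 2-hydroxy-2-methylbutyl on a carbonyl carbon. The closest guide is a 2.7-fold lower number from compound 1 to compound 3 (0.42 log units; beyond the scatter), where 2-hydroxy-2-methylbutyl replaced the ring furan-2-yl. Oxolan-3-yl also puts a ring in that place. The guide is imperfect, since neither ring has been measured against the other. An open chain alone does not secure a lower number: a 1.1-fold lower number from compound 1 to compound 2 (0.05 log units; within the scatter) stays within the scatter, while a 2.4-fold lower number from compound 2 to compound 3 (0.38 log units; beyond the scatter) separates the two hydroxy chains. Compound 2 thus goes against any general advantage of chains over rings.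

A modest move back towards the higher numbers is expected in this assay. The estimated size of that move is a 2.0-fold higher number from compound 3 to compound 4 (0.30 log units; within the scatter). Compound 4 is expected at about 60000 nM, within an estimated range of 25000 nM to 125000 nM.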

Compound 4, half-maximal inhibitory concentration: 73500 nM
For compound 4 the middle estimate is 1.2-fold (0.09 log units) below the measured one; the measured number falls inside the stated range.
By their numbers in this assay, from the lowest: compound 3; then compounds 2, 4 and 1 (each within the scatter of the next).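

In this assay, the step of a 2.4-fold higher number from compound 3 to compound 4 (0.39 log units; beyond the scatter) shows that a ring at this place on the carbonyl carbon does not keep the number reached with 2-hydroxy-2-methylbutyl, so that compound 3 stands beyond the scatter from each of the other three compounds. Among these compounds, the step of a 1.1-fold lower number from compound 1 to compound 4 (0.04 log units; within the scatter) gives the first direct comparison of two rings here, and oxolan-3-yl and furan-2-yl cannot be told apart in this assay. The step of a 1.0-fold higher number from compound 2 to compound 4 (0.01 log units; within the scatter) also places oxolan-3-yl within the scatter of the open 2-hydroxyhexyl chain, so the four compounds show no general split between rings and chains, with compound 2 going against any advantage of chains and compound 3 being the only one that stands apart.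

The change from compound 3 to compound 4 replaces the open chain, its hydroxy group and its defined stereocentre all at once, and a plain 2-methylbutyl chain or a pyrrolidin-3-yl ring, with an amine in place of the ring oxygen, would be needed to separate these parts. The data shown offer no measurement that explains why 2-hydroxy-2-methylbutyl stands apart at this position.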